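Swapping Ethyl for Cyclopropyl on an Amine Side Chain

This account rests on a few compounds, and the source may have more. Where it says the series, first, only, none or still open, it means among the compounds named here.

Compound 1 `Cc1cc(CN(CC2CC2)C(CC(=O)O)c2ccc(Cl)cc2)ccc1OCCn1c(=O)ccn(C)c1=O`: 3000000 nM
Compound 2 `CCCN(Cc1ccc(OCCn2c(=O)ccn(C)c2=O)c(OC)c1)C(CC(=O)O)c1ccc(Cl)cc1`: 3000000 nM

In a physicochemical assay for solubility, at pH 1.1 (a higher number here means a more soluble compound, a lower number a less soluble compound), compound 2 gives 3000000 nM, level with compound 1 at 3000000 nM. Compound 3 `COc1cc(CN(CC2CC2)C(CC(=O)O)c2ccc(Cl)cc2)ccc1OCCn1c(=O)ccn(C)c1=O` is still unmeasured. It differs from compound 2 in one place: cyclopropyl in place of ethyl on a saturated chain carbon bound to an amine nitrogen. Going by the values given here, no measured pair isolates this change. Compound 1 also carries cyclopropyl and gives 3000000 nM, so no shift beyond the scatter is expected in this assay. The estimated change is no change at the digits printed from compound 2 to compound 3 (within the scatter). The estimated value for compound 3 is 3000000 nM, with an expected range of 1500000 nM to 5000000 nM.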

Compound 3, solubility: 3000000 nM
The estimate for compound 3 equals the measured number at the digits printed; measured number inside the range.
By their numbers in this assay, from the lowest: compounds 1, 2 and 3 (each within the scatter of the next).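

In this assay, the swap of ethyl for cyclopropyl on a saturated chain carbon bound to an amine nitrogen now has its own measured pair, which shows no change at the digits printed from compound 2 to compound 3 (within the scatter). The swap of methyl for methoxy on an aromatic carbon also gets its own pair, which shows no change at the digits printed from compound 1 to compound 3 (within the scatter). No supporting measurement accounts for these matching values. Going by these compounds, whether a longer chain such as butyl at the first place, or fluorine at the second, would move the number remains open.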